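This account rests on a few compounds, and the source may have more. Where it says the series, first, only, none or still open, it means among the compounds named here.

Of the compounds shown here, three from this series have been tested in a functional assay on HeLa cells (Homo sapiens) for cytotoxicity, read by MTT assay, with a stated time of 72 h, tested at 100 uM; on this read-out lower numbers stand for less inhibition of growth and higher numbers for more inhibition of growth at the one concentration tested. Compound 3 `Cc1ccnc(/C(N)=N/NC(=S)N2CCSCC2)c1` gives 91.6% there. Compound 1 `Cc1ccnc(/C(N)=N/NC(=S)N2CCOCC2)c1` gives 82.7% in this assay. The two differ in one place, (morpholin-4-yl in place of thiomorpholin-4-yl on a thiocarbonyl carbon), and this change made the step of a number 8.9 percentage points lower from compound 3 to compound 1 (within the scatter). Compound 2 `Cc1cccc(/C(N)=N/NC(=S)N2CCSCC2)n1` is built from the same atoms as compound 3 joined differently; the difference between the two cores is not broken down here. In this assay compound 2 gives 81.6%, and its value and those of compound 1 and compound 3 all lie within the usual scatter of one another, so no order among them can be read from these numbers.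

Compound 4 `Cc1cccc(/C(N)=N/NC(=S)N2CCOCC2)n1` has not yet been measured. It differs from compound 2 by morpholin-4-yl in place of thiomorpholin-4-yl on a thiocarbonyl carbon, the same change as that from compound 3 to compound 1, occurring twice in all among the compounds shown. Since that change produced only a step within the scatter, the step expected from compound 2 to compound 4 is a number 6.6 percentage points lower from compound 2 to compound 4 (within the scatter), resting on a number 8.9 percentage points lower from compound 3 to compound 1 (within the scatter). Compound 4 is accordingly estimated at 75% in this assay, with a likely range from 60% to 88%.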

Compound 4, percent growth inhibition at one concentration: 82.4%
Compound 4: the middle estimate sits 7.4 percentage points below what was measured; low and high end bracket the measured number.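

In this assay, exchanging thiomorpholin-4-yl for morpholin-4-yl on the thiocarbonyl carbon of the second core gave a number 0.8 percentage points higher from compound 2 to compound 4 (within the scatter). Set beside the earlier case, the two steps cannot be told apart: the same change on two cores in this assay, a number 8.9 percentage points lower (within the scatter) from compound 3 to compound 1 and a number 0.8 percentage points higher (within the scatter) from compound 2 to compound 4, 9.7 percentage points apart, within the scatter of two such steps. Within the data shown here, on these two cores, then, the change leaves the read-out within the scatter and nothing separates its outcome on one core from its outcome on the other, but this does not show that the change is without effect, that the two cores respond identically, or that the same would hold on a third core, and it rests on only two pairs at one concentration.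

The compounds shown leave open how other groups on the thiocarbonyl carbon would read, such as piperidin-1-yl, a dimethylamino group or a piperazine ring carrying a methyl group. They also leave open what an ethyl chain or a chlorine in place of the methyl group of the core would do, and whether the two morpholin-4-yl and thiomorpholin-4-yl pairs would stay together at lower concentrations.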